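Pyridyl nitrogen position in a phenol-bearing pyridine series

The compounds below may be only part of what the source reports. "The series", "measured", "known", "first", "only" and "open" are said of these compounds alone.

Compound 1 `Oc1ccc(-c2cc(-c3cccc(Cl)c3)nc(-c3ccccn3)c2)cc1` gives 59.4% in an assay on isolated protein for inhibition of DNA topoisomerase 1 (Homo sapiens), with a stated time of 30 min, tested at 100 uM; a higher number here means a stronger effect of the compound at the concentration tested, a lower number a weaker effect; compound 2 `Oc1ccc(-c2cc(-c3ccncc3)nc(-c3ccccc3Cl)c2)cc1` gives 9.9%; compound 3 `Oc1ccc(-c2cc(-c3cccnc3)nc(-c3cccc(Cl)c3)c2)cc1` gives 55.2%. Compound 3 is second highest of the three, with compound 1 nearest, a number 4.2 percentage points lower from compound 1 to compound 3 (within the scatter), and compound 2 furthest, beyond the scatter. Compound 2 also differs from compound 3 in the chlorophenyl group, so its value does not isolate the pyridyl change. Compound 4 `Oc1ccc(-c2cc(-c3ccncc3)nc(-c3cccc(Cl)c3)c2)cc1` differs from compound 3 only in this way: pyridin-4-yl in place of pyridin-3-yl on an aromatic carbon. Within the data shown here, the one relevant single step, a number 4.2 percentage points lower from compound 1 to compound 3 (within the scatter), was within the scatter, so no large move is expected; the low value of compound 2 still argues for some caution. Compound 4 is therefore expected to show a number 11.2 percentage points lower from compound 3 to compound 4 (beyond the scatter), estimated at 44% with a range of 14% to 65%.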

Compound 4, a percentage reported as inhibition, at one concentration (the size of the read-out at that concentration, not a potency): 29.2%
For compound 4 the middle estimate is 14.8 percentage points above the measured one; the range from low to high includes it.
By their numbers in this assay, from the lowest: compound 2; then compound 4; then compounds 3 and 1 (each within the scatter of the next).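

With the 3-chlorophenyl group held fixed, the position of the pyridyl nitrogen does matter in this assay: the change to pyridin-4-yl gives a number 26 percentage points lower from compound 3 to compound 4 (beyond the scatter) and a number 30.2 percentage points lower from compound 1 to compound 4 (beyond the scatter) while the earlier step between pyridin-2-yl and pyridin-3-yl stayed within the scatter. With pyridin-4-yl held fixed, the chlorine position also counts, as 3-chlorophenyl in place of 2-chlorophenyl gives a number 19.3 percentage points higher from compound 2 to compound 4 (beyond the scatter) and the two changes can therefore be read apart. As far as these compounds go, whether an amine or a carboxylic acid at this place would hold the value remains open. Nothing available explains either step.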